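Indole N-methylation on a longer-chain threonine amide

This account rests on a few compounds, and the source may have more. Where it says the series, first, only, none or still open, it means among the compounds named here.

Measured compounds:
Compound 1, `CCCCCCCCCCCCNC(=O)[C@@H](NC(=O)c1cc2ccccc2[nH]1)[C@@H](C)O`, gives 12300 nM.
Compound 2, `CCCCCCCCCCCCNC(=O)[C@@H](NC(=O)c1cc2ccccc2n1C)[C@@H](C)O`, gives 31300 nM.
Compound 3, `CCCCCCCCCCCCCCCCCCNC(=O)[C@@H](NC(=O)c1cc2ccccc2[nH]1)[C@@H](C)O`, gives 35700 nM.

These three compounds were tested in a functional assay on MCF7 cells (Homo sapiens) for cytotoxicity, read by MTT assay, with a stated time of 48 h; on this read-out higher numbers stand for weaker inhibition and lower numbers for stronger inhibition. Compound 1 and compound 2 differ by one change, (methyl in place of hydrogen on an aromatic nitrogen), and this change gave a 2.5-fold higher number from compound 1 to compound 2 (0.41 log units; beyond the scatter). Compound 1 and compound 3 differ on the other side of the molecule, (hexyl in place of hydrogen on a saturated chain carbon, ten or more bonds along the chain from an amide-type nitrogen), which gave a 2.9-fold higher number from compound 1 to compound 3 (0.46 log units; beyond the scatter). Compound 2 and compound 3 sit close together on this read-out, with no order between them.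

Compound 4, `CCCCCCCCCCCCCCCCCCNC(=O)[C@@H](NC(=O)c1cc2ccccc2n1C)[C@@H](C)O`, has not yet been measured. Among the measured compounds shown here, it differs from compound 3 by methyl in place of hydrogen on an aromatic nitrogen, the same change as the one from compound 1 to compound 2, since the place is described in identical words in both cases. For the measured compounds named here, the step from compound 3 to compound 4 in this assay is therefore expected to resemble the earlier one, because a 2.5-fold higher number from compound 1 to compound 2 (0.41 log units; beyond the scatter) is the only precedent for this change among the compounds in hand, and the expected step is a 2.2-fold higher number from compound 3 to compound 4 (0.35 log units; beyond the scatter). On that basis compound 4 is estimated at 80000 nM, with a plausible range from 35000 nM to 200000 nM.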

Compound 4, half-maximal inhibitory concentration: 36400 nM
Compound 4: the middle estimate sits 2.2-fold (0.34 log units) above what was measured; the range from low to high includes it.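

In this assay, methyl in place of hydrogen on the aromatic nitrogen gave a 1.0-fold higher number from compound 3 to compound 4 (0.01 log units; within the scatter), and the hexyl extension of the chain gave a 1.2-fold higher number from compound 2 to compound 4 (0.07 log units; within the scatter). Although the earlier methyl step lay beyond the scatter and this one lies within it, the two cannot be told apart: the same change on two cores in this assay, a 2.5-fold higher number (0.41 log units; beyond the scatter) from compound 1 to compound 2 and a 1.0-fold higher number (0.01 log units; within the scatter) from compound 3 to compound 4, 2.5-fold (0.40 log units) apart, within the scatter of two such steps. Among the compounds shown here, the hexyl change reads the same way, so with only one pair on each core these compounds neither show that either change carries over at the same size nor show that its size depends on the core: the same change on two cores in this assay, a 2.9-fold higher number (0.46 log units; beyond the scatter) from compound 1 to compound 3 and a 1.2-fold higher number (0.07 log units; within the scatter) from compound 2 to compound 4, 2.5-fold (0.40 log units) apart, within the scatter of two such steps.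

The compounds shown leave open how a shorter chain on the amide nitrogen, or a longer chain than that of compound 3, would read in this assay. They also leave open whether an ethyl group in place of the methyl on the aromatic nitrogen would give a step of any size on either core.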